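Pentyl to Trifluoromethyl: What to Expect of Compound 4

This account rests on a few compounds, and the source may have more. Where it says the series, first, only, none or still open, it means among the compounds named here.

Compound 1 `Cc1ccc(NC(=O)N[C@H](C)c2ccccc2)cc1` gives 100% in an ADME assay on the whole organism with Oryza sativa as the target, tested at 0.1 uM; a lower number here means a stronger effect, a higher number a weaker effect of the compound at the concentration tested.
Compound 2 `C[C@@H](NC(=O)Nc1ccc(C(C)(C)C)cc1)c1ccccc1` gives 100%.
Compound 3 `CCCCCc1ccc(NC(=O)N[C@H](C)c2ccccc2)cc1` gives 100%.

Compound 3 stands level with compounds 1 and 2 at the digits shown. The step of no change at the digits printed from compound 1 to compound 3 (within the scatter) and the step of no change at the digits printed from compound 2 to compound 3 (within the scatter) both lie within the scatter, as does no change at the digits printed from compound 1 to compound 2 (within the scatter). Across these three compounds the group on the aromatic carbon changes from methyl to tert-butyl to pentyl, and the read-out does not move beyond the scatter at any of these steps.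

Compound 4 `C[C@@H](NC(=O)Nc1ccc(C(F)(F)F)cc1)c1ccccc1` has not yet been measured. It differs from compound 3 in one place: trifluoromethyl in place of pentyl on an aromatic carbon

All three measured steps alter the group on this same aromatic carbon, and each of them was flat within the scatter. They therefore point toward no step beyond the scatter for compound 4 either. One reservation remains: trifluoromethyl brings fluorine, which none of compounds 1, 2 and 3 carries, so the measured steps cover this change only in part.

For compound 4 the value in this assay is expected at 98%, within a range from 85% to 100%. The step of a number 2 percentage points lower from compound 3 to compound 4 (within the scatter) is thus expected to stay within the scatter.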

Compound 4, a percentage reported as activity, at one concentration (the size of the read-out at that concentration, not a potency): 93%
Compound 4: middle estimate off by 5 percentage points, on the high side; low and high end bracket the measured number.
By their numbers in this assay, from the lowest: compounds 4, 1, 2 and 3 (each within the scatter of the next).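

In this assay, going by these compounds alone, trifluoromethyl in place of pentyl on this aromatic carbon gives a number 7 percentage points lower from compound 3 to compound 4 (within the scatter), so the first group here to carry fluorine also stays within the scatter. The comparisons with the two other groups read the same way: replacing tert-butyl gives a number 7 percentage points lower from compound 2 to compound 4 (within the scatter), and replacing methyl gives a number 7 percentage points lower from compound 1 to compound 4 (within the scatter). Within the data shown here, this aromatic carbon has now held four different groups, including a fluorine-bearing one, and no step among the four compounds goes beyond the scatter, so swapping pentyl for trifluoromethyl does not set compound 4 apart from the others at the one concentration tested.

Nothing available here explains why the read-out stays this flat across such different groups. The compounds shown leave open whether an amine, a hydroxyl or a carboxylic acid on this aromatic carbon, or a change elsewhere on the shared core, would produce a step beyond the scatter, and whether any of these four compounds would separate from the others at another concentration.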